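The source may hold more compounds than are shown below. What is called first, only, known or untested is meant among the compounds shown, and "the series" means these compounds.

Of the compounds shown here, three with a shared core have been measured so far in a functional assay on MCF7 cells (Homo sapiens) for cytotoxicity, read by MTT assay, with a stated time of 48 h (on this read-out lower numbers stand for stronger inhibition and higher numbers for weaker inhibition), and their numbers lie close together. Compound 1 (`O=C1/C(=C\c2ccc(O)cc2)S/C(=N/c2ccccc2)N1Cc1ccncc1`) gives 18900 nM here, and compound 2 (`O=C1/C(=C\c2ccc([N+](=O)[O-])cc2)S/C(=N/c2ccccc2)N1Cc1ccncc1`) gives 13000 nM here. Compound 3 (`O=C1/C(=C\c2cccc(Cl)c2)S/C(=N/c2ccccc2)N1Cc1ccncc1`) gives 29800 nM at the upper end of the set, above compound 2 and level within the scatter with compound 1. The gap on one side is a 2.3-fold higher number from compound 2 to compound 3 (0.36 log units; beyond the scatter) and counts as modest, while a 1.6-fold higher number from compound 1 to compound 3 (0.20 log units; within the scatter) stays within the scatter, as does a 1.5-fold lower number from compound 1 to compound 2 (0.16 log units; within the scatter) among the other two.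

Compound 4 (`O=C1/C(=C\c2ccccn2)S/C(=N/c2ccccc2)N1Cc1ccncc1`) has not been measured yet. Going by the values given here, the change is pyridin-2-yl in place of 3-chlorophenyl on a double-bonded chain carbon bound to a double-bonded ring carbon and no measured compound carries pyridin-2-yl, so these small steps are the only guide. Each of them alters the same aromatic group and none is large, so only a small move is expected in this assay for this change. Compound 3 at 29800 nM sits at the upper end, so a slightly lower number is the likelier direction. The expected step is a 1.5-fold lower number from compound 3 to compound 4 (0.17 log units; within the scatter) and it would stay within the scatter. For compound 4 the estimated value is 20000 nM with an expected range from 9000 nM to 42000 nM in this measurement.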

Compound 4, half-maximal inhibitory concentration: 21100 nM
Compound 4: middle estimate off by 1.1-fold (0.02 log units), on the low side; measured number inside the range.
By their numbers in this assay, from the lowest: compounds 2, 1, 4 and 3 (each within the scatter of the next, the first and the last beyond it).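

Going by these compounds alone, with pyridin-2-yl, an aromatic ring holding a hetero atom enters this place for the first time, and in this assay the number barely separates from those of the carbon-only aromatic groups: there is a 1.4-fold lower number from compound 3 to compound 4 (0.15 log units; within the scatter), a 1.6-fold higher number from compound 2 to compound 4 (0.21 log units; within the scatter) and a 1.1-fold higher number from compound 1 to compound 4 (0.05 log units; within the scatter). Within the data shown here, all three steps stay within the scatter, so compound 4 adds no new gap, and the only step beyond the scatter remains the one between the 4-nitrophenyl and 3-chlorophenyl compounds. No available evidence accounts for these numbers.

Still open, on these data alone, is whether an amine or a carboxylic acid on this aromatic group, or a longer chain in its place, would leave the same narrow band. The four compounds also leave open how the number responds to pyridin-3-yl or pyridin-4-yl at this place, or to any change elsewhere on the shared core.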